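A few compounds are considered here, and "the series" means these few. Any claim that something is new, unique, unknown or untested is made for them only; others in the source may bear on it.

Measured so far in an ADME assay on MT4 cells (Homo sapiens) for cytotoxicity, read by MTT assay; on this read-out higher numbers stand for lower toxicity in this test and lower numbers for higher toxicity in this test:
compound 1 `O=C1c2ccccc2C(=O)N1CCOC(=S)N(C(=O)c1ccc(Br)cc1)c1ccc(Br)cc1` gives 73000 nM;
compound 2 `O=C1c2ccccc2C(=O)N1CCOC(=S)N(C(=O)c1ccc(Cl)c([N+](=O)[O-])c1)c1ccccc1` gives 51000 nM;
compound 3 `O=C1c2ccccc2C(=O)N1CCOC(=S)N(C(=O)c1cccc(F)c1F)c1ccc(Cl)cc1` gives 58000 nM.

Compound 3 holds the second highest of these three numbers, but its gaps to compound 2 and to compound 1 both lie within the scatter, so no order among the three can be read from them. Compound 4 `O=C1c2ccccc2C(=O)N1CCOC(=S)N(C(=O)c1cc2ccccc2s1)c1ccc(Cl)cc1` differs from compound 3 in one place: 1-benzothiophen-2-yl in place of 2,3-difluorophenyl on a carbonyl carbon. Among the measured compounds shown here, no pair among the measured compounds isolates such a change, so there is nothing to anchor a direction. Given that three rather different acyl groups all land close together, the step from compound 3 to compound 4 is expected to be a 1.1-fold lower number from compound 3 to compound 4 (0.02 log units; within the scatter), that is, nothing beyond the scatter. Compound 4 is therefore estimated at 55000 nM, with a range from 25000 nM to 120000 nM.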

Compound 4, half-maximal cytotoxic concentration: 56000 nM
Compound 4: middle estimate off by 1.0-fold (0.01 log units), on the low side; low and high end bracket the measured number.
By their numbers in this assay, from the lowest: compounds 2, 4, 3 and 1 (each within the scatter of the next).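

In this assay the first change isolated at this position, 1-benzothiophen-2-yl in place of 2,3-difluorophenyl on a carbonyl carbon, gives a 1.0-fold lower number from compound 3 to compound 4 (0.02 log units; within the scatter) and so leaves the number unmoved beyond the scatter. At this carbonyl carbon, a sulfur-bearing aromatic group thus serves like a fluorinated one in this test. No measured evidence accounts for this result. As far as these compounds go, what stays open is whether an acyl group carrying an amine or a carboxylic acid, or a longer alkyl chain on that carbonyl carbon, would shift the number beyond the scatter. Also open, from the compounds shown here alone, is whether this step holds beyond this one pair.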